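The source may hold more compounds than are shown below. What is called first, only, known or untested is meant among the compounds shown, and "the series" means these compounds.

Measured in a functional assay on HepG2 cells (Homo sapiens) for cytotoxicity, read by MTT assay, with a stated time of 24 h; a higher number here means a weaker inhibitor, a lower number a stronger inhibitor:
Compound 1 `O=C1/C(=C/c2cccnc2)CN(S(=O)(=O)c2ccc([N+](=O)[O-])cc2)C/C1=C\c1ccccc1F`: 12800 nM
Compound 2 `O=C1/C(=C/c2ccncc2)CN(S(=O)(=O)c2ccc([N+](=O)[O-])cc2)C/C1=C\c1ccccc1F`: 11300 nM

For the measured compounds named here, compound 2 gives 11300 nM, level with compound 1 at 12800 nM, the only other compound measured so far. The next compound, compound 3 `CC(=O)Nc1ccc(S(=O)(=O)N2C/C(=C\c3ccncc3)C(=O)/C(=C/c3ccccc3F)C2)cc1`, keeps everything in compound 2 except one group: acetamido in place of nitro on an aromatic carbon, para to a large group (acetamido in place of nitro on an aromatic carbon). In other words, 4-nitrophenyl becomes 4-acetamidophenyl.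

Going by the values given here, only one measured step exists, a 1.1-fold lower number from compound 1 to compound 2 (0.05 log units; within the scatter), and it swaps pyridin-3-yl for pyridin-4-yl at a different place in the molecule. It therefore bears only indirectly on the new change. Among the compounds with values here, no measured compound carries anything other than nitro at this place, so the data give no direction for the swap. With that single step inside the scatter, no shift beyond the scatter is expected in this assay, though the uncertainty is wide. The expected result is a 1.2-fold higher number from compound 2 to compound 3 (0.09 log units; within the scatter). For compound 3 the estimated value is 14000 nM, with an expected range from 4000 nM to 40000 nM.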

Compound 3, half-maximal inhibitory concentration: 11700 nM
Compound 3: the middle estimate sits 1.2-fold (0.08 log units) above what was measured; low and high end bracket the measured number.
By their numbers in this assay, from the lowest: compounds 2, 3 and 1 (each within the scatter of the next).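

For the compounds shown here, replacing nitro with acetamido on the aromatic carbon in this assay gives a 1.0-fold higher number from compound 2 to compound 3 (0.02 log units; within the scatter) and provides the first reading of a change at this position, para to a large group. The two groups differ on paper, with nitro counted as 3 heavy atoms and 0 hydrogen-bond donors and acetamido as 4 heavy atoms and 1 hydrogen-bond donor, yet compound 2 and compound 3 cannot be told apart in this cell assay, so this swap leaves the reading unchanged within the usual scatter. No measurement is available that could explain this result.

From the compounds shown here alone, two groups at one position say little about the position as a whole, so it remains open whether an amine, a carboxylic acid, or a chain longer than acetamido at the same aromatic carbon would also leave the number unchanged. It is also open whether acetamido would match nitro in the same way on the pyridin-3-yl compound, compound 1, since the swap is shown here only with pyridin-4-yl in the molecule.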